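This account rests on a few compounds, and the source may have more. Where it says the series, first, only, none or still open, it means among the compounds named here.

- compound 1 `CCCCC(NC(=O)c1ccc(C(=N)N)cc1)C(C)(C)C(=O)N1CCC(CC(=O)O)CC1` at 1.03 h
- compound 2 `CC(C)(C(=O)N1CCC(CC(=O)O)CC1)C(NC(=O)c1ccc(C(=N)N)cc1)c1cccc(O)c1` at 1.08 h

Going by the values given here, in an in vivo ADME assay on the whole organism (Cavia porcellus) (a higher number here means that the compound lasts longer, a lower number that the compound disappears faster), compound 1 stands level with compound 2, and the only step so far, a 1.0-fold higher number from compound 1 to compound 2 (0.02 log units; within the scatter), lies within the scatter. Compound 3 `C#CCN(C(=O)c1ccc(C(=N)N)cc1)C(CCCC)C(C)(C)C(=O)N1CCC(CC(=O)O)CC1` is not yet measured and carries propargyl in place of hydrogen on an amide-type nitrogen on the core of compound 1. Among the compounds with values here, the one measured step of a 1.0-fold higher number from compound 1 to compound 2 (0.02 log units; within the scatter) sits on a saturated chain carbon, not on the amide-type nitrogen, so it is only a weak guide here. With nothing else to go on, no change beyond the scatter is expected, and the estimated step is a 1.1-fold higher number from compound 1 to compound 3 (0.03 log units; within the scatter) in this assay for now. Compound 3 is estimated at 1.1 h with an expected range from 0.6 h to 2.2 h in this series.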

Compound 3, half-life: 1.5 h
For compound 3 the middle estimate is 1.4-fold (0.13 log units) below the measured one, within the range that was stated.
By their numbers in this assay, from the lowest: compounds 1, 2 and 3 (each within the scatter of the next).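

In this assay the amide-type nitrogen carries propargyl in place of hydrogen with a 1.5-fold higher number from compound 1 to compound 3 (0.16 log units; within the scatter) as the result, so this first reading at this position stays within the scatter. The earlier step, a 1.0-fold higher number from compound 1 to compound 2 (0.02 log units; within the scatter), belonged to a saturated chain carbon and said nothing about this nitrogen. No measured evidence bears on the reason for this result.

On these data alone, whether methyl, a longer chain or a chain ending in an amine on this nitrogen would give a step beyond the scatter stays open. So does the effect of propargyl on the core of compound 2, which carries 3-hydroxyphenyl.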